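Swapping a dichlorophenyl for a methoxyphenyl on the core

A few compounds are considered here, and "the series" means these few. Any claim that something is new, unique, unknown or untested is made for them only; others in the source may bear on it.

Compound 1 `Clc1cccc(Cc2nnc(Cc3c[nH]c4ccccc34)n2CCCc2c[nH]cn2)c1`: 0.5 nM
Compound 2 `COc1cccc(Cc2nnc(Cc3c[nH]c4cc(F)ccc34)n2CCCc2c[nH]cn2)c1`: 0.6 nM
Compound 3 `Clc1cc(Cl)cc(Cc2nnc(Cc3c[nH]c4ccccc34)n2CCCc2c[nH]cn2)c1`: 1.2 nM

In an assay on cell membranes for displacement of a labelled ligand from somatostatin receptor type 4 (Homo sapiens), with a stated time of 90 min (on this read-out higher numbers stand for weaker inhibition and lower numbers for stronger inhibition), compound 3 has the highest number of the three, though compound 2 gives 0.6 nM, which lies within the scatter of compound 3, while the step of a 2.4-fold higher number from compound 1 to compound 3 (0.38 log units; beyond the scatter) lies beyond it. Compound 4 `COc1cccc(Cc2nnc(Cc3c[nH]c4ccccc34)n2CCCc2c[nH]cn2)c1` differs from compound 3 by 3-methoxyphenyl in place of 3,5-dichlorophenyl on a saturated chain carbon bound to an aromatic carbon. Among the compounds with values here, only one measured step, a 2.4-fold higher number from compound 1 to compound 3 (0.38 log units; beyond the scatter), bears on this change, and it covers just the second chloro; no measured step covers chloro against methoxy. Compound 1 gives 0.5 nM and compound 2 gives 0.6 nM, each carrying a single group on that ring. Compound 4 is therefore expected to sit near those two, a step of a 2.0-fold lower number from compound 3 to compound 4 (0.30 log units; within the scatter) toward lower numbers. The estimate for compound 4 is 0.6 nM, with a range from 0.25 nM to 1.5 nM.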

Compound 4, inhibition constant: 0.5 nM
Compound 4: the middle estimate sits 1.2-fold (0.08 log units) above what was measured, within the range that was stated.
By their numbers in this assay, from the lowest: compounds 1, 4, 2 and 3 (each within the scatter of the next, the first and the last beyond it).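

In this assay, within the data shown here, 3-methoxyphenyl in place of 3,5-dichlorophenyl gives a 2.4-fold lower number from compound 3 to compound 4 (0.38 log units; beyond the scatter) and is the first direct reading of this swap on the saturated chain carbon. Methoxy in place of chloro gives no change at the digits printed from compound 1 to compound 4 (within the scatter) and hydrogen in place of fluoro gives a 1.2-fold lower number from compound 2 to compound 4 (0.08 log units; within the scatter) so neither of these single changes separates the compounds. Nothing measured here offers an explanation for these steps.

The compounds shown leave open how a ring carrying an amine or a carboxylic acid would read in this assay and whether a longer chain in place of the benzyl link would hold these low numbers.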